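This account rests on a few compounds, and the source may have more. Where it says the series, first, only, none or still open, it means among the compounds named here.

Series notes. The shared core is carried by compound 1 `COc1cc(-c2nn(-c3ccc(NC(=O)c4ccc(Cl)c(Cl)c4)cc3)cc2-c2ccncc2)ccc1Cl`, compound 2 `COc1cc(-c2nn(-c3ccc(NC(=O)c4ccc(Cl)c(C(F)(F)F)c4)cc3)cc2-c2ccncc2)ccc1Cl` and compound 3 `O=C(Nc1ccc(-n2cc(-c3ccncc3)c(-c3ccc(Cl)c(O)c3)n2)cc1)c1ccc(Cl)c(Cl)c1`; compound 4 `O=C(Nc1ccc(-n2cc(-c3ccncc3)c(-c3ccc(Cl)c(O)c3)n2)cc1)c1ccc(Cl)c(C(F)(F)F)c1` is not yet measured. In a functional assay on UACC-257 cells (Homo sapiens) for antiproliferative activity, read by sulforhodamine B assay, with a stated time of 48 h (on this read-out lower numbers stand for stronger inhibition and higher numbers for weaker inhibition), compound 1 reaches only a limit, > 100000 nM, and no number (the limit of > 100000 nM in this assay, at which 1 of the 3 values shown sits). In this assay compound 2 gives 5830 nM. In this assay compound 3 gives 4740 nM, the lower of the two numbers shown, though compound 2 lies within the scatter of it.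

The step to compound 4 is trifluoromethyl in place of chloro on an aromatic carbon. Within the data shown here, two measured steps bear on it. The same exchange on compound 1 gave an at least 17-fold lower number from compound 1 to compound 2 (1.23 log units; beyond the scatter); the other change that separates compound 1 from compound 3 gave an at least 21-fold lower number from compound 1 to compound 3 (1.32 log units; beyond the scatter). Both start from the limit of compound 1, so only a lower bound of each is known. If the two changes add, compound 4 should sit below compound 3, but the measured exchange tells only that it carried compound 1 off its limit, not how far it reaches when the starting point is already a number. In this assay compound 4 is therefore expected at 1200 nM, between 250 nM and 5000 nM. The expected step is a 4.0-fold lower number from compound 3 to compound 4 (0.60 log units; beyond the scatter).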

Compound 4, half-maximal inhibitory concentration: 2550 nM
Compound 4: middle estimate off by 2.1-fold (0.33 log units), on the low side, within the range that was stated.
By their numbers in this assay, from the lowest: compounds 4, 3 and 2 (each within the scatter of the next, the first and the last beyond it). At a limit, above all of these: compound 1.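

In this assay, on the core of compound 3, the change from 3,4-dichlorophenyl to 4-chloro-3-(trifluoromethyl)phenyl gives a 1.9-fold lower number from compound 3 to compound 4 (0.27 log units; within the scatter), so the exchange cannot be told from scatter here and its size depends on the core: the same change on two cores in this assay, an at least 17-fold lower number (1.23 log units; beyond the scatter) from compound 1 to compound 2 and a 1.9-fold lower number (0.27 log units; within the scatter) from compound 3 to compound 4, at least 9.2-fold (0.96 log units) apart, beyond the scatter of two such steps

Hydrogen in place of methyl on the oxygen, read with trifluoromethyl already present, gives only a 2.3-fold lower number from compound 2 to compound 4 (0.36 log units; beyond the scatter), a modest step that is much smaller than the one seen with the 3,4-dichlorophenyl group: the same change on two cores in this assay, an at least 21-fold lower number (1.32 log units; beyond the scatter) from compound 1 to compound 3 and a 2.3-fold lower number (0.36 log units; beyond the scatter) from compound 2 to compound 4, at least 9.2-fold (0.96 log units) apart, beyond the scatter of two such steps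

Compound 1 stands at a limit and not at a number, so the large steps out of it have only a lower bound, and the two changes are not shown to add: the limit of > 100000 nM in this assay, at which 1 of the 4 values shown sits.

Open, as far as these compounds go, is whether a group other than chloro or trifluoromethyl on this aromatic carbon, such as a nitrile or a methyl, moves the number beyond the scatter on the core of compound 3. Also open, from the compounds shown here alone, is whether an amine in place of the hydroxyl of compound 4 keeps or extends the modest step gained over the methyl ether of compound 2.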